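Nitro Removal and Solubility Across Two Glycoside Cores

The source may hold more compounds than are shown below. What is called first, only, known or untested is meant among the compounds shown, and "the series" means these compounds.

Compound 2 `O=[N+]([O-])c1ccc2c(ccn2-c2ccc(O[C@H]3O[C@H](CO)[C@@H](O)[C@H](O)[C@@H]3O)c(F)c2)c1` and compound 1 `OC[C@H]1O[C@H](Oc2ccc(-n3ccc4ccccc43)cc2F)[C@@H](O)[C@@H](O)[C@@H]1O` share one core and differ in a single place: hydrogen in place of nitro on an aromatic carbon. In a physicochemical assay for solubility, using the shake flask method, measured as thermodynamic solubility, with a stated time of 2 h, at pH 6.5 (a higher number here means a more soluble compound, a lower number a less soluble compound), compound 2 gives 4 ug/mL, while compound 1 gives 67 ug/mL, which is a step of a 17-fold higher number from compound 2 to compound 1 (1.22 log units; beyond the scatter). Compound 3 `O=[N+]([O-])c1ccc2c(c1)CCN2c1ccc(O[C@H]2O[C@H](CO)[C@@H](O)[C@H](O)[C@@H]2O)c(Cl)c1` is built on a second core, and the difference between the two cores is not broken down here. In this assay compound 3 gives 3.6 ug/mL. Compound 4 `OC[C@H]1O[C@H](Oc2ccc(N3CCc4ccccc43)cc2Cl)[C@@H](O)[C@@H](O)[C@@H]1O` has not yet been measured; it differs from compound 3 by the same change made before, (hydrogen in place of nitro on an aromatic carbon). Among the measured compounds shown here, compound 4 is expected to gain a step of a 14-fold higher number from compound 3 to compound 4 (1.14 log units; beyond the scatter), much like the earlier step, because a 17-fold higher number from compound 2 to compound 1 (1.22 log units; beyond the scatter) is the only example of this change among the measured compounds. The expected value for compound 4 in this assay is 50 ug/mL, within a range from 20 ug/mL to 130 ug/mL.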

Compound 4, solubility: 21 ug/mL
The estimate for compound 4 lay 2.4-fold (0.38 log units) above the measured number, within the range that was stated.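

In this assay, taking the nitro group off the core of compound 3 again raises the number, with a 5.8-fold higher number from compound 3 to compound 4 (0.77 log units; beyond the scatter), so the direction of the change carries over from the core of compound 2, although this step is numerically smaller than a 17-fold higher number from compound 2 to compound 1 (1.22 log units; beyond the scatter). These two pairs show the same direction on these two cores only, and they do not show that the change would go this way, or reach a similar size, on any other core. No measurement shown here explains the difference in size between the two steps.

The compounds shown leave open what an amine or a carboxylic acid on that aromatic carbon would do to the number. On these data alone, whether either group would give a number closer to the nitro compounds or the hydrogen compounds also remains open.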